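A few compounds are considered here, and "the series" means these few. Any claim that something is new, unique, unknown or untested is made for them only; others in the source may bear on it.

Measured compounds: compound 1 `COC(=O)c1cccc(C#Cc2ccccc2Nc2ncnc3ccc(Cl)nc23)c1` with 4200 nM and compound 2 `CCCNC(=O)c1oc2ccc(Nc3ncnc4ccc(Cl)nc34)cc2c1C` with 1900 nM.

In an assay on isolated protein for inhibition of MAP kinase-interacting serine/threonine-protein kinase 2 (Homo sapiens), read by HTRF, in the presence of a further agent that is not named here (a lower number here means a stronger inhibitor, a higher number a weaker inhibitor), compound 1 gives 4200 nM, the higher of the two numbers recorded. Compound 2 sits nearer the other end; in this assay compound 2 gives 1900 nM, a gap that falls beyond the usual scatter. Within the data shown here, the two compounds differ in more than one place, so no single step connects them and the gap cannot be laid at any one change.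

Compound 3 `CCCNC(=O)c1cccc(C#Cc2ccccc2Nc2ncnc3ccc(Cl)nc23)c1` is the unmeasured partner of compound 1. The difference is a single one: propylamino in place of methoxy on a carbonyl carbon. Among the measured compounds shown here, with no comparable step among the measured pairs, the direction of this change can only be guessed. A step of modest size, towards a somewhat lower number, is expected for the move a 1.7-fold lower number from compound 1 to compound 3 (0.23 log units; within the scatter), though a step no larger than the scatter would not surprise. For compound 3 in this assay the estimate is 2500 nM, with a range from 900 nM to 7000 nM.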

Compound 3, half-maximal inhibitory concentration: 3900 nM
Beside the measured number, compound 3's estimate is 1.6-fold (0.19 log units) below it, and the stated range covers the measured number.
By their numbers in this assay, from the lowest: compound 2; then compounds 3 and 1 (each within the scatter of the next).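

In this assay, the first single change among these compounds, propylamino in place of methoxy on a carbonyl carbon, reads as a 1.1-fold lower number from compound 1 to compound 3 (0.03 log units; within the scatter). At this position, then, methoxycarbonyl and propylcarbamoyl cannot be told apart, even though the exchange adds heavy atoms and a hydrogen-bond donor. No measurement is available that bears on why the two compounds read alike.

Going by these compounds, whether a carboxylic acid, an unsubstituted amide or a longer chain on this carbonyl carbon would give a different number remains open. So does whether a change elsewhere on the core of compound 1 would register in this assay beyond the scatter.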